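This account rests on a few compounds, and the source may have more. Where it says the series, first, only, none or still open, it means among the compounds named here.

Measured compounds in an ADME assay on MT4 cells (Homo sapiens) for cytotoxicity, read by MTT assay; on this read-out higher numbers stand for lower toxicity in this test and lower numbers for higher toxicity in this test:

compound 1, `Cc1nc(NC(=O)NC2CCCCC2)c(C)c(C(OC(C)(C)C)C(=O)O)c1-c1ccc2c(c1C)CCCO2`: 11000 nM
compound 2, `Cc1ccc(-c2c(C)nc(Nc3nc4ccccc4s3)c(C)c2C(OC(C)(C)C)C(=O)O)cc1C`: 6600 nM
compound 3, `Cc1nc(NC(=O)NC2CCCCC2)c(C)c(C(OC(C)(C)C)C(=O)O)c1-c1ccc(Cl)cc1`: 16000 nM

Compound 2 stands lowest of the three numbers in this assay. Its nearest neighbour is compound 1, a gap that lies within the scatter; compound 3 is furthest, and that gap lies beyond the scatter.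

Among the measured compounds shown here, the one step between compounds that differ in a single place is a 1.5-fold higher number from compound 1 to compound 3 (0.16 log units; within the scatter). It concerns the aryl group on the shared core, not the substituent on the ring nitrogen, and so does not bear on the change considered here.

Compound 4, `Cc1ccc(-c2c(C)nc(NC(=O)NC3CCCCCC3)c(C)c2C(OC(C)(C)C)C(=O)O)cc1C`, is not yet measured. It differs from compound 2 as follows: cycloheptylcarbamoyl in place of 1,3-benzothiazol-2-yl on a nitrogen on an aromatic ring

For the measured compounds named here, no measured pair isolates this change. What can be said is that the two compounds carrying a cyclohexylcarbamoyl on the same nitrogen give the following: compound 1 gives 11000 nM and compound 3 gives 16000 nM, while compound 2 with the benzothiazolyl gives 6600 nM. On that basis a move toward the numbers of the carbamoyl-bearing compounds is expected, as a 1.8-fold higher number from compound 2 to compound 4 (0.26 log units; within the scatter), though with the gap to compound 1 within the scatter this may amount to no change beyond the scatter.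

Compound 4 is expected to give 12000 nM in this assay, with a range from 5000 nM to 30000 nM.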

Compound 4, half-maximal cytotoxic concentration: 7700 nM
Estimate against measurement, compound 4: 1.6-fold (0.19 log units) above; the measured number falls inside the stated range.
By their numbers in this assay, from the lowest: compounds 2, 4, 1 and 3 (each within the scatter of the next, the first and the last beyond it).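

Among the compounds shown here, on the nitrogen on an aromatic ring, cycloheptylcarbamoyl in place of 1,3-benzothiazol-2-yl gives in this assay a 1.2-fold higher number from compound 2 to compound 4 (0.07 log units; within the scatter), the first reading of a change at this position from a single pair, and it does not separate the two groups in this test. The exchange removes both aromatic rings of the 1,3-benzothiazol-2-yl and brings in a seven-membered non-aromatic ring of carbon only, a hydrogen-bond donor and a double bond outside aromatic rings, yet the step stays within the scatter, so these differences taken together leave no readable mark on this read-out. No supporting data are available to explain why this exchange leaves the number within the scatter.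

The compounds shown leave open whether ring size within the carbamoyl matters, since cyclohexylcarbamoyl appears only with other aryl groups and cycloheptylcarbamoyl with only one, so no pair compares the two rings directly. They also leave open whether a smaller group on the same nitrogen, such as acetyl or cyclopropylcarbamoyl, or the free amine would stay within the scatter of compound 2.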